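The Same Side-Chain Swap Tried on a Second Core

This account rests on a few compounds, and the source may have more. Where it says the series, first, only, none or still open, it means among the compounds named here.

Measured in a functional assay on the whole organism (Tail, strain ICR) with Mus musculus as the target, in the tail flick test, with a stated time of 120 min, at a dose of 25 umol/kg by the oral route; a higher number here means a stronger effect of the compound at the dose given, a lower number a weaker effect:
compound 1 `CC(C)[C@H](NC(=O)CN(c1nc(Cl)nc2[nH]cnc12)C1CC1)C(=O)OCc1ccccc1` gives 27.3%
compound 2 `CSCC[C@H](NC(=O)CN(c1nc(Cl)nc2[nH]cnc12)C1CC1)C(=O)OCc1ccccc1` gives 31.6%
compound 3 `CSCC[C@H](NC(=O)CN(c1ncnc2c1ncn2C1CCCCO1)C1CC1)C(=O)OCc1ccccc1` gives 28.7%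

Compound 1 and compound 2 share one core, compound 3 carries another; the difference between the two cores is not broken down here, and the values of compound 2 and compound 3 lie within the scatter of each other. Compound 1 differs from compound 2 by isopropyl in place of 2-(methylsulfanyl)ethyl on a saturated chain carbon bound to an amide-type nitrogen and a carbonyl carbon, a change that produced a number 4.3 percentage points lower from compound 2 to compound 1 (within the scatter). Compound 4 `CC(C)[C@H](NC(=O)CN(c1ncnc2c1ncn2C1CCCCO1)C1CC1)C(=O)OCc1ccccc1` differs from compound 3 in the same way, (isopropyl in place of 2-(methylsulfanyl)ethyl on a saturated chain carbon bound to an amide-type nitrogen and a carbonyl carbon), at a place described in identical words. The expected step is a number 3.7 percentage points lower from compound 3 to compound 4 (within the scatter), resting on the step of a number 4.3 percentage points lower from compound 2 to compound 1 (within the scatter) seen on the first core. Compound 4 is therefore estimated at 25%, expected between 13% and 37%.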

Compound 4, a percentage reported as activity, at one dose (the size of the read-out at that dose, not a potency): 25.8%
Beside the measured number, compound 4's estimate is 0.8 percentage points below it; the range from low to high includes it.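

In this assay the swap of 2-(methylsulfanyl)ethyl for isopropyl on the second core gave a number 2.9 percentage points lower from compound 3 to compound 4 (within the scatter) and, set beside the same swap on the first core, it agrees with it: the same change on two cores in this assay, a number 4.3 percentage points lower (within the scatter) from compound 2 to compound 1 and a number 2.9 percentage points lower (within the scatter) from compound 3 to compound 4, 1.4 percentage points apart, within the scatter of two such steps. The change therefore carried over between these two cores without a detectable difference in the size of its step. This does not show that the change has a real effect on the read-out, as each step lies within the scatter, and two cores say nothing about a further one.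

The compounds shown leave open whether a carboxylic acid or an amine on that saturated chain carbon would move the read-out beyond the scatter. Going by these compounds, a longer chain there remains equally open.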